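Cytotoxicity notes: compound 4 as a rearranged dichloro analogue

The compounds below may be only part of what the source reports. "The series", "measured", "known", "first", "only" and "open" are said of these compounds alone.

Measured so far:
compound 1 `COc1ccc(/C=C\C(=O)N2N=C(c3ccncc3)OC2c2c[nH]c3ccccc23)cc1` — > 30 ug/mL, a limit of the assay
compound 2 `O=C(/C=C\c1ccc(Cl)cc1)N1N=C(c2ccncc2)OC1c1c[nH]c2ccccc12` — > 30 ug/mL, a limit of the assay
compound 3 `O=C(/C=C\c1ccc(Cl)cc1Cl)N1N=C(c2ccncc2)OC1c1c[nH]c2ccccc12` — 29.3 ug/mL

Among the compounds with values here, in an ADME assay on HeLa cells (Homo sapiens) for cytotoxicity, read by MTT assay, with a stated time of 72 h (a higher number here means a weaker inhibitor of growth, a lower number a stronger inhibitor of growth), compound 3 gives 29.3 ug/mL, the only plain number among the three. Compound 1 gives only a limit, > 30 ug/mL. Compound 2 likewise gives only a limit, > 30 ug/mL. Two of the three values thus sit at the limit of > 30 ug/mL in this assay, at which 2 of the 3 values shown sit. The steps of an at least 1.0-fold lower number from compound 1 to compound 3 (0.01 log units; that floor lies within the scatter) and an at least 1.0-fold lower number from compound 2 to compound 3 (0.01 log units; that floor lies within the scatter) have floors within the scatter; the step that the two limits leave unreadable from compound 1 to compound 2 cannot be read.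

Compound 4 `O=C(/C=C/c1c(Cl)cccc1Cl)N1N=C(c2ccncc2)OC1c1c[nH]c2ccccc12` differs from compound 3 by 2-(2,6-dichlorophenyl)ethenyl in place of 2-(2,4-dichlorophenyl)ethenyl on a carbonyl carbon. Within the data shown here, no measured step speaks to this rearrangement, and the dichloro steps seen so far stay within the scatter, so no step beyond the scatter is expected, a 1.0-fold higher number from compound 3 to compound 4 (0.01 log units; within the scatter). Compound 4 is estimated at 30 ug/mL, between 15 ug/mL and 60 ug/mL.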

Compound 4, concentration for 50% growth inhibition: > 30 ug/mL
Compound 4: a limit, no number; the forecaster's own chance of this, stated with the estimate: 60%; the middle value lies on the limit itself.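

In this assay compound 4 gives > 30 ug/mL, a limit of the assay and not a number. Placing 2-(2,6-dichlorophenyl)ethenyl on the carbonyl carbon in place of 2-(2,4-dichlorophenyl)ethenyl gives an at least 1.0-fold higher number from compound 3 to compound 4 (0.01 log units; that floor lies within the scatter), so the size of this rearrangement stays unresolved, and the steps from compound 1 and from compound 2 to compound 4 cannot be read. Within the data shown here, compound 3 remains the only compound with a plain number: the limit of > 30 ug/mL in this assay, at which 3 of the 4 values shown sit.

On these data alone, how far compound 4 lies past its limit remains open. Also open, as far as these compounds go, is whether an amine or a carboxylic acid in place of the chlorines would give a readable number in this assay.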